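Moving the Methyl Around the Benzyl Ring

The source may report more compounds than this note shows. Statements on the series, on what has been measured and on what is new or still open speak of the compounds shown alone.

Three measured compounds share one core and differ only in the group on a saturated chain carbon bound to a sulfur. In a functional assay on HeLa cells (Homo sapiens) for antiproliferative activity, read by CCK-8 assay, with a stated time of 48 h (on this read-out lower numbers stand for stronger inhibition and higher numbers for weaker inhibition), compound 1 `CC(C)CSc1n[nH]c(-n2[se]c3ccccc3c2=O)n1` gives 34900 nM, and compound 2 `CCCCCCSc1n[nH]c(-n2[se]c3ccccc3c2=O)n1` gives 35900 nM; the step of a 1.0-fold higher number from compound 1 to compound 2 (0.01 log units; within the scatter) separates them. Compound 3 `Cc1ccccc1CSc1n[nH]c(-n2[se]c3ccccc3c2=O)n1` gives 6130 nM, the lowest of the three numbers, reached through a 5.7-fold lower number from compound 1 to compound 3 (0.76 log units; beyond the scatter) and a 5.9-fold lower number from compound 2 to compound 3 (0.77 log units; beyond the scatter). Compound 4 `Cc1cccc(CSc2n[nH]c(-n3[se]c4ccccc4c3=O)n2)c1` carries the change (3-methylphenyl in place of 2-methylphenyl on a saturated chain carbon bound to a sulfur). Among the compounds with values here, no measured step moves a methyl from one spot of such a ring to another; the measured steps only set an aromatic ring against a chain, and compound 4 keeps the ring. The expected step of a 1.1-fold higher number from compound 3 to compound 4 (0.03 log units; within the scatter) is therefore none beyond the scatter. Compound 4 is expected at 6500 nM, between 2500 nM and 17000 nM.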

Compound 4, half-maximal inhibitory concentration: 42600 nM
Compound 4: middle estimate off by 6.6-fold (0.82 log units), on the low side; the whole stated range lies below it.
By their numbers in this assay, from the lowest: compound 3; then compounds 1, 2 and 4 (each within the scatter of the next).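

In this assay, moving the methyl on the ring matters at this position: 3-methylphenyl in place of 2-methylphenyl gives a 6.9-fold higher number from compound 3 to compound 4 (0.84 log units; beyond the scatter). An aromatic ring alone therefore does not secure the lower number of compound 3, since 3-methylphenyl stands level with the chains, with a 1.2-fold higher number from compound 2 to compound 4 (0.07 log units; within the scatter) and a 1.2-fold higher number from compound 1 to compound 4 (0.09 log units; within the scatter). Nothing available here accounts for this difference.

As far as these compounds go, whether a plain phenyl with no methyl, or a naphthyl group, would follow compound 3 or compound 4 stays open.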